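Swapping the furan for a branched alkyne on a uracil diol

This account rests on a few compounds, and the source may have more. Where it says the series, first, only, none or still open, it means among the compounds named here.

Compounds measured so far:
compound 1 `O=c1[nH]c(=O)n(CCC(CO)CO)cc1-c1ccco1` — 500 nM
compound 2 `CCCCCc1ccc(C#Cc2cn(CCC(COC(C)=O)COC(C)=O)c(=O)n(C(=O)c3ccccc3)c2=O)cc1` — 17600 nM

The two measured compounds were tested in an ADME assay on BJ cells (Homo sapiens) for antiproliferative activity, read by MTT assay, with a stated time of 72 h; on this read-out lower numbers stand for stronger inhibition and higher numbers for weaker inhibition. Compound 1 gives 500 nM, the lower of the two numbers. Compound 2 gives 17600 nM, a number far higher than that of compound 1 and well beyond the scatter of the method; compound 2 also differs from compound 1 in several parts of its structure at once, so no single change can be read from the pair.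

Compound 3 `CC(C)(C)C#Cc1cn(CCC(CO)CO)c(=O)[nH]c1=O` has not yet been measured in this assay. It keeps the diol side chain and the core of compound 1 and differs in one place: 3,3-dimethylbut-1-yn-1-yl in place of furan-2-yl on an aromatic carbon. Within the data shown here, no measured pair isolates this change, so any expectation rests on compound 1 alone.

The expected step from compound 1 to compound 3 is a 3.0-fold higher number from compound 1 to compound 3 (0.48 log units; beyond the scatter), a modest move toward a higher number that may not exceed the scatter. Compound 3 is therefore estimated at 1500 nM, with a likely range from 300 nM to 8000 nM.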

Compound 3, half-maximal inhibitory concentration: 58200 nM
The estimate for compound 3 lay 39-fold (1.59 log units) below the measured number; the whole stated range lies below it.
By their numbers in this assay, from the lowest: compound 1; then compound 2; then compound 3.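

In this assay, among these compounds, this pair gives the first reading of a single change, and replacing furan-2-yl with 3,3-dimethylbut-1-yn-1-yl gives a 120-fold higher number from compound 1 to compound 3 (2.07 log units; beyond the scatter), a large step beyond the scatter. The diol side chain and the rest of the shared core stay the same, so the group on this aromatic carbon, two atoms from the ring nitrogen, can alone move the read-out strongly, which the earlier pair, differing in several parts at once, could not show. Nothing measured here explains the size of this step.

The change removes a five-membered aromatic ring with its oxygen and brings in a triple bond with a branched carbon end, all in one step, so the compounds shown do not separate these features from one another. From the compounds shown here alone, a thiophen-2-yl ring would keep a ring at this carbon, a straight hex-1-yn-1-yl chain would keep the triple bond without the branching, and it remains open where either would fall relative to compound 1 and compound 3.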